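Dichlorofluorophenyl in Place of Trifluorophenyl: Dog Microsome Stability

The compounds below may be only part of what the source reports. "The series", "measured", "known", "first", "only" and "open" are said of these compounds alone.

Measured compounds:
compound 1, `N#Cc1ccc(-c2nc(NCCNc3ccc([N+](=O)[O-])c(N)n3)ncc2-c2ncc[nH]2)cc1`
compound 2, `Nc1nc(NCCNc2ncc(-c3ncc[nH]3)c(-c3cc(F)c(F)cc3F)n2)ccc1[N+](=O)[O-]`

In an ADME assay on microsomes from liver (Canis lupus familiaris) for metabolic stability (on this read-out higher numbers stand for a longer-lived compound and lower numbers for a shorter-lived compound), compound 1 gives only a limit of the assay, > 0.5 h. Compound 2 likewise gives only a limit, > 0.5 h. The step that the two limits leave unreadable from compound 1 to compound 2 is therefore unreadable. Compound 2 stands at the limit of > 0.5 h in this assay, at which 2 of the 2 values shown sit, where every value shown sits. Compound 3 `Nc1nc(NCCNc2ncc(-c3ncc[nH]3)c(-c3cc(F)c(Cl)cc3Cl)n2)ccc1[N+](=O)[O-]` differs from compound 2 by 2,4-dichloro-5-fluorophenyl in place of 2,4,5-trifluorophenyl on an aromatic carbon. Among the measured compounds shown here, no measured step bears on this change, and the two limits give neither size nor direction. The step from compound 2 to compound 3 in this assay is expected to be a step that the limit leaves unreadable from compound 2 to compound 3. Compound 3 is estimated at 1 h, between 0.4 h and 3 h.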

Compound 3, half-life: > 0.5 h
Compound 3 was reported as a limit (the forecaster's own chance of this, stated with the estimate: 75%); the middle value lies beyond the limit too.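

In this assay compound 1, compound 2 and compound 3 all sit at one limit, so no step among them can be read: the limit of > 0.5 h in this assay, at which 3 of the 3 values shown sit.

From the compounds shown here alone, the actual half-lives of these three compounds, and whether exchanging the group on that aromatic carbon changes them at all, remain open.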